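This account rests on a few compounds, and the source may have more. Where it says the series, first, only, none or still open, it means among the compounds named here.

For the measured compounds named here, compound 2, with the structure `CCCCc1ccc(-n2cc(-c3cn([C@H]4C[C@H](O)[C@@H](CO)O4)c(=O)[nH]c3=O)nn2)cc1`, is one of two compounds measured in an ADME assay on HeLa cells (Homo sapiens) for cytotoxicity, read by cell counting, with a stated time of 4 days; a lower number here means a stronger inhibitor, a higher number a weaker inhibitor. Compound 2 gives 23000 nM, the highest number of the two. Its nearest neighbour is compound 1, structure `O=c1[nH]c(=O)n([C@H]2C[C@H](O)[C@@H](CO)O2)cc1-c1cn(-c2c(F)cccc2F)nn1`, which in this assay gives 510 nM. Going by the values given here, the one step that links them, a 45-fold higher number from compound 1 to compound 2 (1.65 log units; beyond the scatter), shows that the group on the aromatic nitrogen of the triazole governs this read-out strongly.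

Compound 3, structure `O=c1[nH]c(=O)n([C@H]2C[C@H](O)[C@@H](CO)O2)cc1-c1cn(-c2ccc(Oc3ccccc3)cc2)nn1`, differs from compound 2 in a single place: phenoxy in place of butyl on an aromatic carbon. Among the compounds with values here, no measured pair mirrors this exchange; the only recorded step concerns a different swap on the same aryl group, so it speaks for the sensitivity of this position without fixing a direction. A further large move in either direction is therefore possible, and a step within the scatter cannot be ruled out.

Compound 3 is accordingly expected to give about 15000 nM in this assay, with a broad range from 3000 nM to 60000 nM; the expected step of a 1.5-fold lower number from compound 2 to compound 3 (0.19 log units; within the scatter) is small and uncertain.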

Compound 3, half-maximal inhibitory concentration: 280 nM
For compound 3 the middle estimate is 54-fold (1.73 log units) above the measured one, and the stated range ends above it.
By their numbers in this assay, from the lowest: compounds 3 and 1 (each within the scatter of the next); then compound 2.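

In this assay, for the compounds shown here, the earlier step showed only that the aryl group on the triazole matters. The exchange at the aromatic carbon para to a large group now shows that this single place is enough to move the read-out by a wide margin, and in a known direction: an 82-fold lower number from compound 2 to compound 3 (1.91 log units; beyond the scatter). Compound 2 and compound 3 both carry a large group on that carbon, yet their numbers lie far apart. Compound 3 at 280 nM and compound 1 at 510 nM lie within the scatter of each other. Nothing available here explains why phenoxy and butyl differ so sharply.

The exchange brings in the aromatic ring and the oxygen together, so the compounds shown leave open which of the two goes with the lower number, a question that benzyl or a plain phenyl group on the same carbon would address. They also leave open how a longer chain than butyl, an amine or a carboxylic acid at this place would read in this assay.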